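The compounds below may be only part of what the source reports. "The series", "measured", "known", "first", "only" and "open" are said of these compounds alone.

Measured compounds:
- compound 1, `CN1CCN(c2ccc(Nc3ncc4c(n3)N(C3CCCC3)CC(=O)N4)cc2)CC1`, > 30000 nM
- compound 2, `CN1C(=O)CN(C2CCCC2)c2nc(Nc3ccc(N4CCCCC4)cc3)ncc21`, 25300 nM
- compound 3, `CC1CCN(c2ccc(Nc3ncc4c(n3)N(C3CCCC3)CC(=O)N4C)cc2)CC1`, "not determined" (no result reported)

The three measured compounds share one core and were tested in an ADME assay on HEK293 cells (Homo sapiens) for inhibition, read by MTT assay, with a stated time of 48 h; a higher number here means a weaker inhibitor, a lower number a stronger inhibitor. For compound 1 the value of > 30000 nM is a limit of the assay, not a number. Compound 2 gives 25300 nM in this assay. Compound 3 has no reported result in this assay and is recorded as "not determined" (no result reported), so it stands nowhere on the numbers shown. Among the compounds with values here, the only further value shown belongs to compound 1, (the limit of > 30000 nM in this assay, at which 1 of the 3 values shown sits).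

Compound 4, `CCN1C(=O)CN(C2CCCC2)c2nc(Nc3ccc(N4CCC(C)CC4)cc3)ncc21`, is not yet measured. It differs from compound 3 by one change, (methyl in place of hydrogen on a saturated chain carbon bound to an amide-type nitrogen in a ring). Within the data shown here, no step between two measured compounds is available to set the size of this change. The nearest point of reference is compound 2 with its value of 25300 nM in this assay, a compound carrying the same methyl on the amide-type nitrogen as compound 3 and a piperidine without the methyl. On that basis a step from compound 3 to compound 4 of no size beyond the scatter, in no particular direction, is expected. Compound 4 is therefore estimated to give 25000 nM in this assay, within a range from 8000 nM to 60000 nM.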

Compound 4, half-maximal inhibitory concentration: > 30000 nM
Compound 4 was reported as a limit (the forecaster's own chance of this, stated with the estimate: 45%); middle value at least 1.2-fold (0.07 log units) from the limit.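

No step can be read between compound 3, which has no reported result, and compound 4, whose value is a limit of the assay and not a number: the limit of > 30000 nM in this assay, at which 2 of the 4 values shown sit.

The compounds shown leave open what size of effect, if any, the change from hydrogen to methyl at this place has in this assay.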